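Furan-2-yl in place of 1H-pyrrol-2-yl: working notes

The source may hold more compounds than are shown below. What is called first, only, known or untested is meant among the compounds shown, and "the series" means these compounds.

In a functional assay on SGC-7901 cells (Homo sapiens) for cytotoxicity, read by MTT assay, with a stated time of 38 h (on this read-out higher numbers stand for weaker inhibition and lower numbers for stronger inhibition), compound 1 `COc1cc(OC)c2c(=O)c(OCC(=O)N/N=C/c3sccc3C)c(-c3cc(OC)c(OC)c(OC)c3)oc2c1` gives 10300 nM, compound 2 `COc1cc(OC)c2c(=O)c(OCC(=O)N/N=C/c3ccc(C)cc3)c(-c3cc(OC)c(OC)c(OC)c3)oc2c1` gives 10100 nM, and compound 3 `COc1cc(OC)c2c(=O)c(OCC(=O)N/N=C/c3ccc[nH]3)c(-c3cc(OC)c(OC)c(OC)c3)oc2c1` gives 8730 nM. Compound 3 therefore stands within the scatter of both other compounds. The next structure is compound 4 `COc1cc(OC)c2c(=O)c(OCC(=O)N/N=C/c3ccco3)c(-c3cc(OC)c(OC)c(OC)c3)oc2c1`, with furan-2-yl in place of 1H-pyrrol-2-yl on a carbon with a double bond to nitrogen. Three measured steps exchange the group at this place: a 1.0-fold lower number from compound 1 to compound 2 (0.01 log units; within the scatter), a 1.2-fold lower number from compound 1 to compound 3 (0.07 log units; within the scatter) and a 1.2-fold lower number from compound 2 to compound 3 (0.06 log units; within the scatter). All lie within the scatter, so no step beyond it is expected in this assay. The expected change is a 1.1-fold higher number from compound 3 to compound 4 (0.04 log units; within the scatter), within the scatter. For compound 4, the estimated value is 9500 nM, with an expected range of 5000 nM to 18000 nM.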

Compound 4, half-maximal inhibitory concentration: 5720 nM
The estimate for compound 4 lay 1.7-fold (0.22 log units) above the measured number; the measured number falls inside the stated range.
By their numbers in this assay, from the lowest: compounds 4, 3, 2 and 1 (each within the scatter of the next).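

Among these compounds, the furan-2-yl ring, with 1 hydrogen-bond acceptor and 0 hydrogen-bond donors, is the first group here to remove the donor of 1H-pyrrol-2-yl while keeping a five-membered aromatic ring with 1 hetero atom. In this assay this exchange gives a 1.5-fold lower number from compound 3 to compound 4 (0.18 log units; within the scatter); the wider exchanges give a 1.8-fold lower number from compound 2 to compound 4 (0.25 log units; within the scatter) and a 1.8-fold lower number from compound 1 to compound 4 (0.26 log units; within the scatter). All four groups at this place thus remain within the scatter of one another, and no evidence on the cause of these numbers is available.

Going by these compounds, whether any group here can give a step beyond the scatter remains open. A carboxylic acid, an amine or a longer chain on the carbon with a double bond to nitrogen would test that.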